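From a methyl to a phenyl on an amine nitrogen

The compounds below may be only part of what the source reports. "The series", "measured", "known", "first", "only" and "open" are said of these compounds alone.

Compound 3 `CN1CCN(CC(=O)Nc2ccc(-c3nc(-c4ccccc4)c(-c4ccccc4)n3C)cc2)CC1` gives 49.1% in a functional assay on HT-29 cells (Homo sapiens) for cytotoxicity, read by MTT assay, with a stated time of 24 h, tested at 32 ug/mL (a lower number here means a weaker effect, a higher number a stronger effect of the compound at the concentration tested), the lowest of the three numbers. Compound 1 `Cn1c(-c2ccc(NC(=O)CCl)cc2)nc(-c2ccccc2)c1-c1ccccc1` gives 53.2% in this assay, and the step of a number 4.1 percentage points lower from compound 1 to compound 3 (within the scatter) is within the scatter. Compound 2 `Cn1c(-c2ccc(NC(=O)CSc3nc4ccccc4s3)cc2)nc(-c2ccccc2)c1-c1ccccc1` gives 66% in this assay, and the step of a number 16.9 percentage points lower from compound 2 to compound 3 (beyond the scatter) is beyond it. Compound 4 `Cn1c(-c2ccc(NC(=O)CN3CCN(c4ccccc4)CC3)cc2)nc(-c2ccccc2)c1-c1ccccc1` differs from compound 3 in one place: phenyl in place of methyl on an amine nitrogen in a ring. Among the compounds with values here, no measured step alters a group on an amine nitrogen in a ring; all three change the group on the saturated chain carbon bound to a carbonyl carbon, so none bears directly on this change. Compound 4 is therefore expected to show at most a modest step, a number 5.9 percentage points higher from compound 3 to compound 4 (within the scatter), in this assay. The estimate for compound 4 is 55%, with a range from 42% to 68%.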

Compound 4, a percentage reported as activity, at one concentration (the size of the read-out at that concentration, not a potency): 60.5%
Beside the measured number, compound 4's estimate is 5.5 percentage points below it, within the range that was stated.
By their numbers in this assay, from the lowest: compounds 3, 1, 4 and 2 (each within the scatter of the next, the first and the last beyond it).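

In this assay, within the data shown here, phenyl in place of methyl on an amine nitrogen in a ring gives a change beyond the scatter (a number 11.4 percentage points higher from compound 3 to compound 4 (beyond the scatter)), the only measured step at this position. With 4-phenylpiperazin-1-yl on the chain carbon, the other steps (a number 5.5 percentage points lower from compound 2 to compound 4 (within the scatter); a number 7.3 percentage points higher from compound 1 to compound 4 (within the scatter)) lie within the scatter, so this group separates from neither the (1,3-benzothiazol-2-yl)sulfanyl nor the chloro compound, whereas 4-methylpiperazin-1-yl stood apart from the former. No measured evidence bears on the reason for the step. The compounds shown leave open how a benzyl group, a pyridine ring or an acetyl group on that nitrogen would read, and whether a fluorine on the added phenyl would move the number.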